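The source may report more compounds than this note shows. Statements on the series, on what has been measured and on what is new or still open speak of the compounds shown alone.

Measured so far in a functional assay on K562 cells (Homo sapiens) for cytotoxicity, read by XTT assay, with a stated time of 24 h; on this read-out higher numbers stand for weaker inhibition and lower numbers for stronger inhibition: compound 1 `Cc1ccc(NC(=O)c2ccc(OCCCCn3ccnc3)c(Br)c2)cc1Nc1nccc(-c2cccnc2)n1` gives 12000 nM; compound 2 `Cc1ccc(OCCCCn2ccnc2)c(C(=O)Nc2ccc(C)c(Nc3nccc(-c4cccnc4)n3)c2)c1` gives 59500 nM; compound 3 `Cc1ccc(NC(=O)c2cc(I)ccc2OCCCCn2ccnc2)cc1Nc1nccc(-c2cccnc2)n1` gives 66500 nM.

Compound 1 has the lowest number of the three, and both compound 2 and compound 3 stand beyond the scatter above it. Compound 4 `Cc1ccc(NC(=O)c2ccc(OCCCCn3ccnc3)c(I)c2)cc1Nc1nccc(-c2cccnc2)n1` differs from compound 1 by iodo in place of bromo on an aromatic carbon. Among the compounds with values here, the only measured step of one change, a 1.1-fold higher number from compound 2 to compound 3 (0.05 log units; within the scatter), puts iodo in place of methyl and lies within the scatter; no measured step exchanges bromo for iodo, so nothing bears directly on this change. With no pull in either direction, no step beyond the scatter is expected, and the expected step is no change at the digits printed from compound 1 to compound 4 (within the scatter). Compound 4 is therefore estimated at 12000 nM, with a range from 5000 nM to 30000 nM.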

Compound 4, half-maximal inhibitory concentration: 32500 nM
Compound 4: middle estimate off by 2.7-fold (0.43 log units), on the low side, and the stated range ends below it.
By their numbers in this assay, from the lowest: compound 1; then compounds 4, 2 and 3 (each within the scatter of the next, the first and the last beyond it).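

At this position, ortho to a 4-(1H-imidazol-1-yl)butoxy group, the choice of halogen matters in this assay: iodo in place of bromo gives a 2.7-fold higher number from compound 1 to compound 4 (0.43 log units; beyond the scatter), a modest step. Within the data shown here, the only earlier step, a 1.1-fold higher number from compound 2 to compound 3 (0.05 log units; within the scatter), lay at another place and stayed within the scatter, so a swap of one atom can be seen to count here. Nothing measured explains this step. Going by these compounds, whether chloro or plain hydrogen at this position would continue the trend remains open, as does whether a longer chain in place of the butoxy group would alter the size of the step.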